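The source may hold more compounds than are shown below. What is called first, only, known or untested is meant among the compounds shown, and "the series" means these compounds.

Measured in a functional assay on HT-29 cells (Homo sapiens) for inhibition, read by MTT assay; a lower number here means a stronger inhibitor, a higher number a weaker inhibitor:

- Compound 1 `COc1ccc2c(c1)CC[C@H](O)/C2=C/c1cc(OC)c(OC)c(OC)c1`: 1 nM
- Compound 2 `COc1ccc2c(c1)CC[C@@H](O)/C2=C/c1cc(OC)c(OC)c(OC)c1`: 900 nM
- Compound 3 `COc1ccc(/C=C2\c3cc(OC)c(OC)c(OC)c3CC[C@@H]2O)cc1[N+](=O)[O-]`: 1590 nM

Compound 3, at 1590 nM, lies within the scatter of compound 2, and far from compound 1 at 1 nM. Compound 4 `COc1ccc(/C=C2\c3cc(OC)c(OC)c(OC)c3CC[C@H]2O)cc1[N+](=O)[O-]` is its counterpart: the two compounds have the same atoms and bonds and differ only in configuration as drawn: 1 of 2 stereo elements differ; a stereocentre at a saturated ring carbon is drawn S in compound 3 and R in compound 4. Within the data shown here, one measured step bears on this change, a 900-fold higher number from compound 1 to compound 2 (2.95 log units; beyond the scatter), a large step that comes with the fact that compounds 1 and 2 differ only in the configuration as drawn. There too a stereocentre at a saturated ring carbon goes from S to R, so a move to a higher number in this assay is expected. The substituents of compound 3 differ from those of compound 1, however, so that step may not carry over in full, and its direction is also uncertain. The expected change is therefore smaller than the measured one: a 3.1-fold higher number from compound 3 to compound 4 (0.50 log units; beyond the scatter), as an estimate. For compound 4 the estimated value is 5000 nM, with an expected range from 100 nM to 50000 nM.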

Compound 4, half-maximal inhibitory concentration: > 10000 nM
Compound 4 ended at the assay's limit; the forecaster's own chance of this, stated with the estimate: 15%; at least 2.0-fold (0.30 log units) between middle value and limit.
By their numbers in this assay, from the lowest: compound 1; then compounds 2 and 3 (each within the scatter of the next). At a limit, above all of these: compound 4.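

In this assay, the move from S to R at the saturated ring carbon raises the number a second time, now in a pair with different substituents: an at least 6.2-fold higher number from compound 3 to compound 4 (0.79 log units; beyond the scatter). Compound 4 stands at a limit of the assay, > 10000 nM, not at a measured number. The earlier step, a 900-fold higher number from compound 1 to compound 2 (2.95 log units; beyond the scatter), is therefore no longer alone in its direction, and here too the shift comes with configuration only: the fact that compounds 3 and 4 differ only in the configuration as drawn.

How far this step really reaches stays unread, so its size cannot be set against the earlier one: the limit of > 10000 nM in this assay, at which 1 of the 4 values shown sits. From the compounds shown here alone, whether the same order of the two configurations holds with an amine in place of the nitro group, or with a methyl ether in place of the hydroxyl, remains open.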